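The source may hold more compounds than are shown below. What is called first, only, known or untested is meant among the compounds shown, and "the series" means these compounds.

Within the data shown here, compound 1 `Oc1cc2cc(c1)Oc1c(O)cc(cc1O)[C@H](O)CCCCCCCCCCCCC2` and compound 2 `COc1cc(O)cc(CCCCCCC/C=C/CCCCCc2cc(O)cc(O)c2)c1` are the two measured members. In an ADME assay on MCF7 cells (Homo sapiens) for cytotoxicity (a higher number here means a weaker inhibitor, a lower number a stronger inhibitor), compound 1 gives 30600 nM, and compound 2 gives 29800 nM; the two numbers sit within the usual scatter of each other, so neither compound can be ranked ahead of the other. Compound 3 `Oc1cc(O)cc(CCCCC/C=C/CCCCCCCc2cc(O)cc(O)c2)c1` has not yet been measured. It differs from compound 2 only by hydrogen in place of methyl on an oxygen on an aromatic ring. Among the measured compounds shown here, no measured pair shows this change, so the step is expected to be small, with no direction beyond the scatter, an estimated 1.1-fold lower number from compound 2 to compound 3 (0.03 log units; within the scatter). For compound 3 the expected value in this assay is 28000 nM, with a range from 11000 nM to 70000 nM.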

Compound 3, half-maximal inhibitory concentration: 28600 nM
Estimate against measurement, compound 3: 1.0-fold (0.01 log units) below; measured number inside the range.
By their numbers in this assay, from the lowest: compounds 3, 2 and 1 (each within the scatter of the next).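

Among these compounds, the methoxy to hydroxy swap gives the first readable step: in this assay it reads a 1.0-fold lower number from compound 2 to compound 3 (0.02 log units; within the scatter). On this oxygen on an aromatic ring, methyl and hydrogen therefore cannot be told apart in this read-out, so the methyl is not needed to hold the value of compound 2. No supporting measurement bears on this result.

From the compounds shown here alone, whether a larger group on the same oxygen, such as benzyl, would behave likewise remains open. So does replacing the hydroxy with an amine or a carboxylic acid.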